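The compounds below may be only part of what the source reports. "The series", "measured", "known", "first", "only" and "open" are said of these compounds alone.

Compound 3 `CN(C)C1(Cc2ccccc2)CCN(c2cc(C(F)(F)F)ccc2CNC(=O)Nc2cccc3[nH]c(=O)ccc23)CC1` gives the lowest number among the three compounds measured in an assay on CHO cells for displacement of a labelled ligand from transient receptor potential cation channel subfamily V member 1 (Homo sapiens), read by scintillation counting, with a stated time of 60 min (on this read-out higher numbers stand for weaker inhibition and lower numbers for stronger inhibition), at 1.67 nM. Compound 1 `CN(C)C1(Cc2ccccc2)CCN(c2cc(C(F)(F)F)ccc2CNC(=O)Nc2ccc(CO)c(F)c2)CC1` gives 27.9 nM, and compound 2 `CN(C)C1(Cc2ccccc2)CCN(c2cc(C(F)(F)F)ccc2CNC(=O)Nc2ccc3c(c2)OCC3)CC1` gives 41.4 nM. The step of a 17-fold lower number from compound 1 to compound 3 (1.22 log units; beyond the scatter) and the step of a 25-fold lower number from compound 2 to compound 3 (1.39 log units; beyond the scatter) both show that the group present in compound 3 on the amide-type nitrogen gives a markedly lower number than either of the alternatives, while the step of a 1.5-fold higher number from compound 1 to compound 2 (0.17 log units; within the scatter) shows little separation between those two alternatives.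

Compound 4 `CN(C)C1(Cc2ccccc2)CCN(c2cc(C(F)(F)F)ccc2CNC(=O)Nc2ccc3cccnc3c2)CC1` differs from compound 3 in that place: a group of 10 heavy atoms (9 carbon, 1 nitrogen; one six-membered aromatic ring of carbon only, one six-membered aromatic ring with 1 hetero atom) in place of a group of 11 heavy atoms (9 carbon, 1 nitrogen, 1 oxygen; one six-membered aromatic ring of carbon only, one six-membered aromatic ring with 1 hetero atom), on an amide-type nitrogen. Of the measured steps, none exchanges exactly these two groups; the steps that end at compound 3 only show how far it stands from compounds 1 and 2. The entering group keeps the two fused six-membered rings, but the hydrogen-bond donor and the double bond outside the aromatic rings leave. For the measured compounds named here, with no direct precedent, the expected outcome is a number somewhat higher than that of compound 3, though not as high as compounds 1 and 2, an expected step of a 5.4-fold higher number from compound 3 to compound 4 (0.73 log units; beyond the scatter). Compound 4 is therefore estimated to give 9 nM in this assay, within a range of 3 nM to 35 nM.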

Compound 4, inhibition constant: 14.1 nM
For compound 4 the middle estimate is 1.6-fold (0.19 log units) below the measured one, within the range that was stated.
By their numbers in this assay, from the lowest: compound 3; then compounds 4, 1 and 2 (each within the scatter of the next, the first and the last beyond it).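

In this assay, an 8.4-fold higher number from compound 3 to compound 4 (0.93 log units; beyond the scatter) shows that keeping two fused six-membered aromatic rings on the amide-type nitrogen does not preserve the low number of compound 3: quinolin-7-yl has the same ring count, yet it lacks the hydrogen-bond donor and the double bond outside the aromatic rings. Against the other groups the picture is uneven: a 2.9-fold lower number from compound 2 to compound 4 (0.47 log units; beyond the scatter) separates quinolin-7-yl from the group of compound 2, whereas a 2.0-fold lower number from compound 1 to compound 4 (0.30 log units; within the scatter) leaves it indistinguishable from 3-fluoro-4-(hydroxymethyl)phenyl, so among these compounds, a second six-membered aromatic ring alone does not set a group apart from that single-ring group. No accompanying measurement explains these differences.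

The exchange removes the hydrogen-bond donor and the carbonyl together, so the compounds shown do not reveal which of the two matters, or whether both do. A methyl group on the ring nitrogen of the group in compound 3 would keep the carbonyl and lose the donor, while an amine on quinolin-7-yl would restore a donor without the carbonyl.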